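The source may report more compounds than this note shows. Statements on the series, on what has been measured and on what is new or still open speak of the compounds shown alone.

In an ADME assay on MRC5 cells (Homo sapiens) for inhibition, read by MTT assay, with a stated time of 72 h (a lower number here means a stronger inhibitor, a higher number a weaker inhibitor), compound 1 `CO[C@@H]1[C@H]2OC(=O)C[C@H]2O[C@@H]1[C@@H](O)c1ccccc1` gives > 100000 nM, which is a limit and not a number. Compound 2 `CO[C@@H](c1ccccc1)[C@H]1O[C@@H]2CC(=O)O[C@@H]2[C@H]1O` stands at > 100000 nM, also a limit. Compound 3 `CO[C@H](c1ccccc1)[C@H]1O[C@@H]2CC(=O)O[C@@H]2[C@H]1O` reads > 100000 nM, again a limit. The picture so far is therefore (the limit of > 100000 nM in this assay, at which 3 of the 3 values shown sit), and compound 2 has no number of its own from which to count.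

The change from compound 2 to compound 4 `CO[C@@H]1[C@H]2OC(=O)C[C@H]2O[C@@H]1[C@@H](OC)c1ccccc1` is methyl in place of hydrogen on an oxygen on a saturated carbon. Cut one bond further out, it reads hydroxy to methoxy.

For the measured compounds named here, only one measured step sits near this change: a step that the two limits leave unreadable from compound 2 to compound 3. That step bears on it only weakly, as it concerns the fact that compounds 2 and 3 differ only in the configuration as drawn rather than an exchange of groups, and it gives no size to carry over. Going by the values given here, no measured step covers methyl in place of hydrogen on an oxygen. With all three values at the limit, no step beyond the scatter is expected in this assay, and no direction can be assigned.

The expected step is a number no higher from compound 2 to compound 4 (the limit leaves the size open), an estimate only. Compound 4 is estimated at 100000 nM, with an expected range of 50000 nM to 200000 nM, and the assay is expected to report it as a limit.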

Compound 4, half-maximal inhibitory concentration: 87600 nM
Beside the measured number, compound 4's estimate is 1.1-fold (0.06 log units) above it; the measured number falls inside the stated range.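

In this assay, for the compounds shown here, compound 4 gives 87600 nM, the first value that is a number and not a limit, which gives the series a point from which later steps can be counted. The hydroxy to methoxy change can now be read from two starting points, first as an at least 1.1-fold lower number from compound 2 to compound 4 (0.05 log units; that floor lies within the scatter) and then, with methyl in place of hydrogen on an oxygen on a saturated carbon once more, as an at least 1.1-fold lower number from compound 1 to compound 4 (0.05 log units; that floor lies within the scatter). Neither floor establishes a real shift, and the series otherwise stays at the limit: the limit of > 100000 nM in this assay, at which 3 of the 4 values shown sit.

How much higher the true numbers of compound 1 and compound 2 lie cannot be read from these limits, and the step between the two configurations of compound 2 and compound 3 cannot be read either. From the compounds shown here alone, it remains open whether an ethoxy group or an amine on the same saturated carbon would move the number beyond the scatter, and whether the opposite configuration at the methoxy-bearing carbon of compound 4 would read any differently.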